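Methoxy to hydroxy on compound 3

The source may hold more compounds than are shown below. What is called first, only, known or untested is meant among the compounds shown, and "the series" means these compounds.

Three compounds of the series have so far been run in an assay on isolated protein for inhibition of thiosulfate sulfurtransferase (Homo sapiens), with a stated time of 60 min, in the absence of a further agent; on this read-out lower numbers stand for stronger inhibition and higher numbers for weaker inhibition. Compound 1 `O=C(Nc1ccc(Sc2nc3ccccc3s2)c(Cl)c1)c1cccc(Br)c1` reports only a limit of the assay, > 100000 nM. Compound 2 `O=C(Nc1ccc(Sc2nc3ccccc3s2)cc1)c1ccccc1O` likewise reports only a limit, > 100000 nM. Compound 3 `COc1ccccc1C(=O)Nc1ccc(Sc2nc3ccccc3s2)c(Cl)c1` also reports only a limit, > 100000 nM. Within the data shown here, all three values rest at the limit (the limit of > 100000 nM in this assay, at which 3 of the 3 values shown sit), so compound 3 stands nowhere readable against the other two and no compound separates from any other. Among the measured compounds shown here, the single one-point step, a step that the two limits leave unreadable from compound 1 to compound 3, cannot be read in size or direction.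

Compound 4 `O=C(Nc1ccc(Sc2nc3ccccc3s2)c(Cl)c1)c1ccccc1O` differs from compound 3 by hydrogen in place of methyl on an oxygen on an aromatic ring. For the measured compounds named here, no measured step matches this change. Going by the values given here, the only framing comes from compound 2, which already carries the hydroxy group and rests at a limit, and compound 3, which carries the methoxy group and rests at a limit. Both ends of the change are therefore unreadable, and nothing in the series marks any compound out from the rest. Among the compounds with values here, for compound 4 the expected outcome in this assay is a further limit, with a step that the limit leaves unreadable from compound 3 to compound 4 expected to be no step readable beyond the scatter. Compound 4 is accordingly estimated at 150000 nM, in a range from 40000 nM to 600000 nM.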

Compound 4, half-maximal inhibitory concentration: > 100000 nM
Compound 4 gave a limit, no number (the forecaster's own chance of this, stated with the estimate: 85%); the middle value does not contradict the limit.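

No step to compound 4 from compound 1, compound 2 or compound 3 can be read, because all four values are limits: the limit of > 100000 nM in this assay, at which 4 of the 4 values shown sit.

The compounds shown leave open what effect, if any, methoxy to hydroxy, chloro in place of hydrogen, or 2-hydroxyphenyl in place of 3-bromophenyl has on inhibition, as none of the four gives a number.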